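This account rests on a few compounds, and the source may have more. Where it says the series, first, only, none or still open, it means among the compounds named here.

Measured so far:
Compound 1 `COc1cc(C2CC(c3ccccc3)=NN2C(=O)OCc2ccccc2)cc(OC)c1OC` gives > 10000 nM in a functional assay on HT-29 cells (Homo sapiens) for antiproliferative activity, read by MTT assay, with a stated time of 48 h (a lower number here means a stronger inhibitor of growth, a higher number a weaker inhibitor of growth), and this is a limit of the assay rather than a number.
Compound 2 `COc1cccc(C2=NN(C(=O)OCc3ccccc3)C(c3cc(OC)c(OC)c(OC)c3)C2)c1` gives > 10000 nM in this assay, again only a limit.
Compound 3 `COC(=O)N1N=C(c2ccccc2)CC1c1ccc(OC)cc1` gives > 10000 nM in this assay, again only a limit.

Going by the values given here, the one structural change that can be followed between measured compounds is methoxy in place of hydrogen on an aromatic carbon. As far as these compounds go, the step it made in this assay is a step that the two limits leave unreadable from compound 1 to compound 2, so its size is unknown. The difference between the core of compound 1 and the core of compound 3 is not broken down here.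

Compound 4 `COC(=O)N1N=C(c2ccccc2)CC1c1ccc(OC)c(OC)c1` has not yet been measured. It differs from compound 3 by methoxy in place of hydrogen on an aromatic carbon. Among the compounds with values here, this is the same kind of change as the one from compound 1 to compound 2, but not the same: in compound 4 the entering methoxy sits ortho to a methoxy group and meta to a large group, whereas in compound 2 it sits meta to a large group, the change reading phenyl to 3-methoxyphenyl when cut one bond further out.

For compound 4 the step expected in this assay is a step that the limit leaves unreadable from compound 3 to compound 4. That expectation rests on compound 3, whose result of > 10000 nM is only a limit, and on the fact that the earlier change from compound 1 to compound 2 could not be read because of the limit of > 10000 nM in this assay, at which 3 of the 3 values shown sit. Compound 4 is therefore estimated at 20000 nM, between 5000 nM and 100000 nM, and most likely reported again as a limit only.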

Compound 4, concentration for 50% growth inhibition: 10700 nM
Compound 4: the middle estimate sits 1.9-fold (0.27 log units) above what was measured; measured number inside the range.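

In this assay compound 3 gives > 10000 nM, which is a limit of the assay and not a number. The size of the step to compound 4 from compound 3, which gains a methoxy group, therefore cannot be read. The compounds shown leave open how much an added methoxy on an aromatic carbon changes growth inhibition, since most results stop at one value: the limit of > 10000 nM in this assay, at which 3 of the 4 values shown sit.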